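The compounds below may be only part of what the source reports. "The series", "measured", "known", "first", "only" and "open" are said of these compounds alone.

Measured compounds:
compound 1 `Cc1ccc(S(=O)(=O)/N=C(/CCNC2=CC(=O)c3ccccc3C2=O)Nc2ccc(F)cc2)cc1` — 55100 nM
compound 2 `COc1ccc(N/C(CCNC2=CC(=O)c3ccccc3C2=O)=N\S(=O)(=O)c2ccc(C)cc2)c(OC)c1` — 83000 nM

In an ADME assay on HEK293 cells (Homo sapiens) for cytotoxicity, read by MTT assay, with a stated time of 48 h (a higher number here means a weaker inhibitor, a lower number a stronger inhibitor), compound 2 holds the highest of the two numbers, with compound 1 the nearest, though that gap is within the scatter. Among the measured compounds shown here, the one measured step that bears on the new compound is a 1.5-fold higher number from compound 1 to compound 2 (0.18 log units; within the scatter), a change of one substituted phenyl for another on the same amine nitrogen, which produced no shift beyond the scatter.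

Compound 3 `COc1cc(N/C(CCNC2=CC(=O)c3ccccc3C2=O)=N\S(=O)(=O)c2ccc(C)cc2)cc(OC)c1OC` differs from compound 2 by 3,4,5-trimethoxyphenyl in place of 2,4-dimethoxyphenyl on an amine nitrogen. For the measured compounds named here, since the only comparable step, a 1.5-fold higher number from compound 1 to compound 2 (0.18 log units; within the scatter), stayed within the scatter, the expectation is that this further exchange of one methoxy-bearing phenyl for another also produces no step beyond the scatter in this assay. Compound 3 is therefore estimated to give about 80000 nM, with a range from 35000 nM to 180000 nM, and the expected step is a 1.0-fold lower number from compound 2 to compound 3 (0.02 log units; within the scatter).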

Compound 3, half-maximal inhibitory concentration: 75800 nM
Beside the measured number, compound 3's estimate is 1.1-fold (0.02 log units) above it; the range from low to high includes it.
By their numbers in this assay, from the lowest: compounds 1, 3 and 2 (each within the scatter of the next).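

In this assay, the exchange on this amine nitrogen now reaches 3,4,5-trimethoxyphenyl, with a 1.1-fold lower number from compound 2 to compound 3 (0.04 log units; within the scatter) and, against the fluorinated group, a 1.4-fold higher number from compound 1 to compound 3 (0.14 log units; within the scatter) as the second new step. Even with more heavy atoms and more hydrogen-bond acceptors than the group it replaces, the entering group gives no step beyond the scatter, so compounds 1, 2 and 3 show three different substituted phenyl groups at this place with no separation in this read-out. No supporting measurement accounts for this result.

From the compounds shown here alone, all three compounds keep a substituted phenyl on this nitrogen, so it remains open whether a phenyl carrying an amine or a carboxylic acid, or a simple alkyl chain in its place, would give a step beyond the scatter. Going by these compounds, the rest of the structure is shared by all three, which leaves the effect of any change there, such as a longer chain in the linker, equally open.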